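The compounds below may be only part of what the source reports. "The series", "measured", "known", "first", "only" and "open" are said of these compounds alone.

Compound 1 `COc1cc(Cl)c(C(=O)Nc2cccc(-c3nc4ccccc4s3)c2)cc1[N+](=O)[O-]` is the less soluble of the two compounds measured in a physicochemical assay for solubility, read by spectrophotometry, in phosphate buffer, measured as kinetic solubility, with a stated time of 18 h, at pH 7.4 (a lower number here means a less soluble compound, a higher number a more soluble compound), giving 10 nM. Its nearest neighbour, compound 2 `Cc1ccc(-c2nc3ccccc3s2)cc1NC(=O)c1cc([N+](=O)[O-])c(N(C)C)cc1Cl`, gives 30 nM in this assay, a gap that lies beyond the usual scatter of repeated measurements. Within the data shown here, no single-point step between measured compounds is available, so the comparison with compound 2 only shows that two compounds sharing this core can sit at different levels. Compound 3 `O=C(O)COc1cc(Cl)c(C(=O)Nc2cccc(-c3nc4ccccc4s3)c2)cc1[N+](=O)[O-]` has not yet been measured; it differs from compound 1 by carboxy in place of hydrogen on a saturated chain carbon bound to an oxygen on an aromatic ring. Among the measured compounds shown here, no measured pair shows what such a change does here, so the expectation rests on compound 1 alone. Compound 3 is expected to show a move upward from compound 1 of about a 10-fold higher number from compound 1 to compound 3 (1.00 log units; beyond the scatter), larger than the scatter. The solubility of compound 3 in this assay is therefore estimated at 100 nM, with a range from 20 nM to 500 nM.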

Compound 3, solubility: 6700 nM
Compound 3: the middle estimate sits 67-fold (1.83 log units) below what was measured; the measured number lies above the stated range.
By their numbers in this assay, from the lowest: compound 1; then compound 2; then compound 3.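

In this assay, replacing hydrogen with carboxy on a saturated chain carbon bound to an oxygen on an aromatic ring, which turns methoxy into carboxymethoxy, comes with a 670-fold higher number from compound 1 to compound 3 (2.83 log units; beyond the scatter) on the core of compound 1. This is the only single-place step shown, and it establishes that a change at this position can move the read-out far beyond the usual scatter, which the gap between the two earlier compounds could not show. The data shown offer no measured account of why the step is this large.

As far as these compounds go, it remains open whether this size of step is specific to carboxy, or whether an amine on the same chain carbon would move the number as far. A longer chain ending in a carboxylic acid is equally unresolved, as is whether the step would carry over to other compounds with the shared core.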